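The source may hold more compounds than are shown below. What is called first, only, known or untested is meant among the compounds shown, and "the series" means these compounds.

Going by the values given here, in an assay on isolated protein for inhibition of tyrosine-protein kinase receptor UFO (Homo sapiens), read by LC-MS (a lower number here means a stronger inhibitor, a higher number a weaker inhibitor), compound 3 `Cc1nn(C)c(C)c1-c1ccc(-c2nnc(N(C)Cc3ccc4nccn4c3)o2)c(F)c1` gives 1260 nM, the lowest of the two numbers known so far. Its nearest neighbour, compound 2 `CN(Cc1ccc2nccn2c1)c1nnc(-c2ccc(-c3ccccc3)cc2)o1`, gives 3160 nM in this assay. Compound 1 `CN(Cc1ccc2nccn2c1)c1nnc(-c2ccccc2)o1` gives > 100000 nM in this assay, which is a limit of the assay rather than a number. Among the compounds with values here, the only step measured is an at least 31-fold lower number from compound 1 to compound 2 (1.50 log units; beyond the scatter), and its true size is not known since compound 1 sits at the limit of > 100000 nM in this assay, at which 1 of the 3 values shown sits.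

Compound 4 `Cc1cc(-c2c(C)nn(C)c2C)ccc1-c1nnc(N(C)Cc2ccc3nccn3c2)o1` differs from compound 3 in one place: methyl in place of fluoro on an aromatic carbon. Within the data shown here, none of the measured steps bears directly on this change. Among the measured compounds shown here, the single step measured so far concerns a phenyl added in place of a hydrogen, a change of a quite different kind from swapping one small group for another on a ring that is already fully built out, so it gives little guidance here. For the measured compounds named here, with no comparable step on hand, the expectation is that exchanging fluoro for methyl moves this assay by no more than the usual scatter, that is, a step of no change at the digits printed from compound 3 to compound 4 (within the scatter) is expected. The estimate for compound 4 is therefore 1260 nM, with a range from 400 nM to 4000 nM.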

Compound 4, half-maximal inhibitory concentration: 79.4 nM
For compound 4 the middle estimate is 16-fold (1.20 log units) above the measured one; measured number below the stated range.
By their numbers in this assay, from the lowest: compound 4; then compound 3; then compound 2. At a limit, above all of these: compound 1.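

The position in question, on an aromatic carbon ortho to a large group and meta to a 1,3,5-trimethyl-1H-pyrazol-4-yl group, turns out to be sensitive in this assay: methyl in place of fluoro gives a 16-fold lower number from compound 3 to compound 4 (1.20 log units; beyond the scatter), so swapping one small group for another here is not a neutral change. The earlier step showed a large change only on adding a whole phenyl, whereas here one heavy atom replaces one heavy atom, with no hydrogen-bond donor, hydrogen-bond acceptor or net charge counted on either side. Nothing measured here explains why methyl and fluoro differ so much at this position.

Whether the lower number is particular to methyl remains open, since the compounds shown do not include ethyl, methoxy, chloro or an amine at this position. On these data alone, this change also rests on a single pair of compounds, so it is unknown whether it would give a step of similar size with another group in place of the 1,3,5-trimethyl-1H-pyrazol-4-yl group.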